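Moving a methoxy group on a thiosemicarbazone: an expectation

The source may report more compounds than this note shows. Statements on the series, on what has been measured and on what is new or still open speak of the compounds shown alone.

Compound 1 `COc1ccccc1NC(=S)N/N=C/c1ccc2ccccc2n1`: > 100000 nM in a functional assay on SGC-7901 cells (Homo sapiens) for antiproliferative activity, read by sulforhodamine B assay, with a stated time of 72 h (on this read-out lower numbers stand for stronger inhibition and higher numbers for weaker inhibition), a limit of the assay rather than a number.
Compound 2 `NC(=S)N/N=C/c1cc2cccnc2s1`: 100000 nM in this assay.
Compound 3 `NC(=S)N/N=C/c1cc2ccccc2s1`: > 100000 nM in this assay, again a limit.

Within the data shown here, compound 1 therefore stands at the edge of what this assay can report, described by the limit of > 100000 nM in this assay, at which 2 of the 3 values shown sit, and no measured pair differing in one place is available to show how large a single change can be here. Compound 4 `COc1cccc(NC(=S)N/N=C/c2ccc3ccccc3n2)c1` carries 3-methoxyphenyl in place of 2-methoxyphenyl on an amide-type nitrogen, a 3-methoxyphenyl in place of 2-methoxyphenyl on an amide-type nitrogen. In this assay the step of a number no higher from compound 1 to compound 4 (the limit leaves the size open) is expected to be none beyond the usual scatter. Compound 4 is estimated at 100000 nM, within a range from 30000 nM to 300000 nM, most likely reported only as a limit.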

Compound 4, half-maximal inhibitory concentration: 79400 nM
Compound 4: the middle estimate sits 1.3-fold (0.10 log units) above what was measured; the measured number falls inside the stated range.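

Swapping in 3-methoxyphenyl for 2-methoxyphenyl on an amide-type nitrogen gives the first comparison of a single change in this assay, with an at least 1.2-fold lower number from compound 1 to compound 4 (0.10 log units; that floor lies within the scatter) on record. Compound 4 reaches a measured number rather than a limit, yet it stays weak, so this move of the methoxy group brings no clear gain. As far as these compounds go, the true size of the step stays unknown because one end of it is a limit: the limit of > 100000 nM in this assay, at which 2 of the 4 values shown sit.

From the compounds shown here alone, whether an amine or a carboxylic acid in place of the methoxy group would lower the number much further remains open.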